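This account rests on a few compounds, and the source may have more. Where it says the series, first, only, none or still open, it means among the compounds named here.

Compound 1 `COc1cccc(CNc2ncnc3c2ncn3C2CCCCO2)c1O` gives > 100000 nM in an ADME assay on K562 cells (Homo sapiens) for cytotoxicity, with a stated time of 72 h (on this read-out lower numbers stand for stronger inhibition and higher numbers for weaker inhibition), which is a limit of the measurement rather than a number. Compound 2 `Oc1cccc(CNc2ncnc3c2ncn3C2CCCCO2)c1O` gives 92000 nM in this assay. Compound 3 `COc1ccc(CNc2ncnc3c2ncn3C2CCCO2)cc1OC` gives > 100000 nM in this assay, again only a limit.

The change from compound 1 to compound 2 is hydrogen in place of methyl on an oxygen on an aromatic ring. It made an at least 1.0-fold lower number from compound 1 to compound 2 (0.03 log units; that floor lies within the scatter), and since the starting point is the limit of > 100000 nM in this assay, at which 2 of the 3 values shown sit, the true size of that step is not known. Compound 1 and compound 3 contain the same atoms joined differently; the difference between the two cores is not broken down here.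

Compound 4 `COc1cc(CNc2ncnc3c2ncn3C2CCCO2)ccc1O` has not yet been measured in this assay. Among the compounds with values here, it differs from compound 3 by hydrogen in place of methyl on an oxygen on an aromatic ring, the same change as the one from compound 1 to compound 2, made at a place described in the same words. The step from compound 3 to compound 4 is expected to be a number no higher from compound 3 to compound 4 (the limit leaves the size open), an expectation resting on an at least 1.0-fold lower number from compound 1 to compound 2 (0.03 log units; that floor lies within the scatter) and on the limit reported for compound 3. Compound 4 is therefore expected to give about 100000 nM in this assay, somewhere between 40000 nM and 300000 nM, with a real chance that only a limit is reported once more.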

Compound 4, half-maximal inhibitory concentration: > 100000 nM
Compound 4: a limit, no number (the forecaster's own chance of this, stated with the estimate: 60%); the middle value lies on the limit itself.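

No step can be read between compound 3 and compound 4, as each carries only a limit in this assay, and the result adds one more to the values resting there: the limit of > 100000 nM in this assay, at which 3 of the 4 values shown sit.

The compounds shown leave open how large the change from methoxy to hydroxy truly is on either core, and where compound 1, compound 3 and compound 4 truly stand.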